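A few compounds are considered here, and "the series" means these few. Any claim that something is new, unique, unknown or untested is made for them only; others in the source may bear on it.

In a functional assay on SMMC-7721 cells (Homo sapiens) for cytotoxicity, read by MTT assay, with a stated time of 24 h (a higher number here means a weaker inhibitor, a lower number a stronger inhibitor), compound 1 (`COc1cc(/C=C2\CN(C)C/C(=C\c3cccnc3)C2=O)cc(OC)c1`) gives 17900 nM while compound 2 (`CN1C/C(=C\c2cccnc2)C(=O)/C(=C/c2ccccc2F)C1`) gives 5420 nM and compound 3 (`CN1C/C(=C\c2cccnc2)C(=O)/C(=C/c2cc([N+](=O)[O-])ccc2F)C1`) gives 6170 nM as its reading. Compound 3 therefore stands within the scatter of compound 2 and beyond the scatter under compound 1. Compound 4 (`CN1C/C(=C\c2ccncc2)C(=O)/C(=C/c2cc([N+](=O)[O-])ccc2F)C1`) has the same atoms as compound 3, joined differently: pyridin-4-yl in place of pyridin-3-yl on a double-bonded chain carbon bound to a double-bonded ring carbon on a double-bonded chain carbon bound to a double-bonded ring carbon. Among the measured compounds shown here, the only measured step (a 1.1-fold higher number from compound 2 to compound 3 (0.06 log units; within the scatter)) placed nitro in place of hydrogen on an aromatic carbon, lay within the scatter and left the pyridine untouched. It gives only indirect guidance, so no shift beyond the scatter is expected in this assay here. The expected step is a 1.0-fold lower number from compound 3 to compound 4 (0.01 log units; within the scatter) and lies within the scatter. Compound 4 is estimated at 6000 nM with an expected range from 3000 nM to 12000 nM for this reading.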

Compound 4, half-maximal inhibitory concentration: 14700 nM
Compound 4: middle estimate off by 2.5-fold (0.39 log units), on the low side; the whole stated range lies below it.
By their numbers in this assay, from the lowest: compounds 2 and 3 (each within the scatter of the next); then compounds 4 and 1 (each within the scatter of the next).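

The pyridine at this place is not neutral in this assay: pyridin-4-yl in place of pyridin-3-yl gives a 2.4-fold higher number from compound 3 to compound 4 (0.38 log units; beyond the scatter), although the atoms stay the same. Among the compounds shown here, the only earlier step, a 1.1-fold higher number from compound 2 to compound 3 (0.06 log units; within the scatter), changed the other aryl ring and stayed within the scatter, so this is the first sign that the reading responds to a change in the shared structure. Nothing available here accounts for the shift.

Going by these compounds, it remains open how pyridin-2-yl or a plain phenyl ring would read at this place. On these data alone, whether the same pyridine change gives a similar step without the nitro group also remains open.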